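The source may hold more compounds than are shown below. What is called first, only, known or untested is meant among the compounds shown, and "the series" means these compounds.

Three compounds share one core and differ only in the group on a saturated chain carbon bound to a carbonyl carbon. Compound 1 `Cn1c(-c2ccc(NC(=O)CCl)cc2)nc(-c2ccccc2)c1-c1ccccc1` gives 7.2% in a functional assay on HT-29 cells (Homo sapiens) for cytotoxicity, read by MTT assay, with a stated time of 24 h, tested at 0.64 ug/mL; on this read-out lower numbers stand for a weaker effect and higher numbers for a stronger effect at the one concentration tested. Compound 2 `Cc1ccc2oc(SCC(=O)Nc3ccc(-c4nc(-c5ccccc5)c(-c5ccccc5)n4C)cc3)nc2c1` gives 11%. Compound 3 `Cn1nnnc1SCC(=O)Nc1ccc(-c2nc(-c3ccccc3)c(-c3ccccc3)n2C)cc1` gives 38%, the highest of the three numbers, beyond the scatter from both others. Compound 4 `CN1CCN(CC(=O)Nc2ccc(-c3nc(-c4ccccc4)c(-c4ccccc4)n3C)cc2)CC1` has not yet been measured; it differs from compound 3 by 4-methylpiperazin-1-yl in place of (1-methyl-1H-tetrazol-5-yl)sulfanyl on a saturated chain carbon bound to a carbonyl carbon. The two earlier steps at this same place were a number 30.8 percentage points higher from compound 1 to compound 3 (beyond the scatter) and a number 27 percentage points higher from compound 2 to compound 3 (beyond the scatter), so exchanging this group has already moved the number widely, and the entering group resembles none of the three tested. The expected step is a number 18 percentage points lower from compound 3 to compound 4 (beyond the scatter), downward and beyond the scatter, though with much uncertainty. Compound 4 is therefore estimated at 20%, between 5% and 45%.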

Compound 4, a percentage reported as activity, at one concentration (the size of the read-out at that concentration, not a potency): 18.8%
Beside the measured number, compound 4's estimate is 1.2 percentage points above it, and the stated range covers the measured number.
By their numbers in this assay, from the lowest: compounds 1, 2 and 4 (each within the scatter of the next, the first and the last beyond it); then compound 3.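

The 4-methylpiperazin-1-yl group shows that a group attached without sulfur can still change the number at this position: in this assay the exchange gives a number 11.6 percentage points higher from compound 1 to compound 4 (beyond the scatter) and also a number 19.2 percentage points lower from compound 3 to compound 4 (beyond the scatter). Sulfur alone does not set the result, since the exchange gives a number 7.8 percentage points higher from compound 2 to compound 4 (within the scatter) even though only the group leaving compound 2 carries sulfur. No supporting evidence explains these differences.

As far as these compounds go, it remains open where morpholin-4-yl or dimethylamino on the same chain carbon would fall. From the compounds shown here alone, it is also open whether a tetrazole ring attached without sulfur would retain the number of compound 3.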